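Dropping the Benzyloxy from a Compound at the Limit

The compounds below may be only part of what the source reports. "The series", "measured", "known", "first", "only" and "open" are said of these compounds alone.

Compound 3 `O=C(/C=C/c1ccc(F)cc1)c1ccc(OCc2ccccc2)cc1` gives > 50000 nM in a functional assay on CAL-51 cells (Homo sapiens) for inhibition, read by sulforhodamine B assay, with a stated time of 3 days; a higher number here means a weaker inhibitor of growth, a lower number a stronger inhibitor of growth. Among the measured compounds shown here, that value is a limit of the assay and not a number, and it is the only limit among the three values measured so far. Compound 4 `O=C(/C=C/c1ccc(F)cc1)c1ccccc1` has hydrogen in place of benzyloxy on an aromatic carbon, para to a large group: hydrogen in place of benzyloxy on an aromatic carbon.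

Two other compounds offer a guide. In this assay, compound 1 `O=C(/C=C/c1ccc(OCc2ccccc2)cc1)c1ccccc1` gives 24700 nM, and compound 2 `O=C(/C=C/c1ccc(Cl)cc1)c1ccccc1` gives 5850 nM. For the measured compounds named here, the one measured step, chloro in place of benzyloxy on an aromatic carbon, is a 4.2-fold lower number from compound 1 to compound 2 (0.63 log units; beyond the scatter). It is a modest change, but beyond the scatter. It took place at a different site, though, and put chloro rather than hydrogen in the vacated position, so it is only an indirect guide. Compound 2, at 5850 nM, also shows that a molecule without benzyloxy can give a clear number in this test. Going by the values given here, compound 4 likewise has no benzyloxy, but it carries fluoro where compound 2 carries chloro, and no measured step covers that swap.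

A lower number is therefore expected, and the estimated move is an at least 5.5-fold lower number from compound 3 to compound 4 (0.74 log units; beyond the scatter), which is rough given the limit at its start. Compound 4 is expected to give about 9000 nM, with an estimated range of 3000 nM to 27000 nM.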

Compound 4, concentration for 50% growth inhibition: 2780 nM
Compound 4: the middle estimate sits 3.2-fold (0.51 log units) above what was measured; the whole stated range lies above it.
By their numbers in this assay, from the lowest: compound 4; then compound 2; then compound 1. At a limit, above all of these: compound 3.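

Hydrogen in place of benzyloxy on this aromatic carbon gives an at least 17-fold lower number from compound 3 to compound 4 (1.25 log units; beyond the scatter) in this assay, so this position now has a direct reading, where the earlier step came from a different site and put chloro in the vacated place. Going by these compounds, compound 3 stands at a limit of the assay and not at a number, and the true size of this step stays unknown because its starting point is that limit: the limit of > 50000 nM in this assay, at which 1 of the 4 values shown sits. With fluoro on the other ring, compound 4 also gives the lowest number of the four, with a 2.1-fold lower number from compound 2 to compound 4 (0.32 log units; beyond the scatter) for fluoro in place of chloro and an 8.9-fold lower number from compound 1 to compound 4 (0.95 log units; beyond the scatter) for fluoro in place of benzyloxy, and the two compounds that carry benzyloxy sit highest in this small set.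

The compounds shown leave open how a methoxy group, an amine or a carboxylic acid on this aromatic carbon would compare with hydrogen. They also leave open whether a shorter chain ending in the same aromatic ring would behave like benzyloxy or like hydrogen.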